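Butylsulfanyl in Place of Dimethylamino: Cytotoxicity Outlook

The source may hold more compounds than are shown below. What is called first, only, known or untested is meant among the compounds shown, and "the series" means these compounds.

Three compounds sharing one core have been examined in an ADME assay on BCBL1 cells (Homo sapiens) for cytotoxicity, with a stated time of 7 days; a higher number here means that more compound is tolerated, a lower number that less compound is tolerated. Compound 1 `CN(C)c1nc(N)nc2c1ncn2/C=C1/CC1(CO)CO` is reported only as a limit, > 20000 nM. Compound 2 `CC(C)CNc1nc(N)nc2c1ncn2/C=C1/CC1(CO)CO` likewise stops at the limit > 20000 nM. Compound 3 `CCCCOc1nc(N)nc2c1ncn2/C=C1/CC1(CO)CO` also stands at the limit > 20000 nM. Because the limit of > 20000 nM in this assay, at which 3 of the 3 values shown sit, holds throughout, the steps a step that the two limits leave unreadable from compound 1 to compound 2, a step that the two limits leave unreadable from compound 1 to compound 3 and a step that the two limits leave unreadable from compound 2 to compound 3 cannot be sized. Compound 4 `CCCCSc1nc(N)nc2c1ncn2/C=C1/CC1(CO)CO` differs from compound 1 by butylsulfanyl in place of dimethylamino on an aromatic carbon. Going by the values given here, no measured step gives a readable size for this change, so the expected step of a number no higher from compound 1 to compound 4 (the limit leaves the size open) is none beyond the scatter. Compound 4 is therefore expected to give 20000 nM in this assay, within 10000 nM to 40000 nM.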

Compound 4, half-maximal cytotoxic concentration: > 20000 nM
Compound 4 was reported as a limit; the forecaster's own chance of this, stated with the estimate: 80%; the middle value sits exactly at the limit.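

Compound 4 yields no readable step against compound 1, compound 2 or compound 3 in this assay, because all four values are limits, not numbers: the limit of > 20000 nM in this assay, at which 4 of the 4 values shown sit.

The compounds shown leave open how far their tolerated concentrations differ, if at all.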